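The source may hold more compounds than are shown below. What is called first, only, known or untested is meant among the compounds shown, and "the series" means these compounds.

Measured in an ADME assay on BJ cells (Homo sapiens) for cytotoxicity, read by MTT assay, with a stated time of 72 h; a higher number here means that more compound is tolerated, a lower number that less compound is tolerated:
Compound 1 `OC[C@H]1O[C@@H](n2cc(Cl)c3c(-c4ccccc4)ncnc32)[C@H](O)[C@@H]1O` gives 44500 nM.
Compound 2 `OC[C@H]1O[C@@H](n2cc(Cl)c3c(-c4ccoc4)ncnc32)[C@H](O)[C@@H]1O` gives 21600 nM.

Going by the values given here, compound 2 holds the lower of the two numbers, and the only measured step is a 2.1-fold lower number from compound 1 to compound 2 (0.31 log units; beyond the scatter). Compound 3 `OC[C@H]1O[C@@H](n2cc(Cl)c3c(-c4ccsc4)ncnc32)[C@H](O)[C@@H]1O` differs from compound 2 in one place: thiophen-3-yl in place of furan-3-yl on an aromatic carbon. Among the compounds with values here, no measured step covers this exchange of one five-membered ring for another. Within the data shown here, the single known step, from phenyl to furan-3-yl, was modest, so a step of at most similar size is expected in this assay, with no firm direction. Compound 3 is estimated at 28000 nM, in the range 12000 nM to 65000 nM. The expected step is a 1.3-fold higher number from compound 2 to compound 3 (0.11 log units; within the scatter).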

Compound 3, half-maximal cytotoxic concentration: 1720 nM
For compound 3 the middle estimate is 16-fold (1.21 log units) above the measured one; measured number outside the range, below it.
By their numbers in this assay, from the lowest: compound 3; then compound 2; then compound 1.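

In this assay, the exchange of furan-3-yl for thiophen-3-yl on this aromatic carbon gives a 13-fold lower number from compound 2 to compound 3 (1.10 log units; beyond the scatter) and shows that two five-membered aromatic rings of equal heavy-atom count, differing in the hetero atom, can lie far apart. Measured against phenyl, thiophen-3-yl gives a 26-fold lower number from compound 1 to compound 3 (1.41 log units; beyond the scatter), a much larger step than furan-3-yl gave. No supporting measurement explains this difference. The compounds shown leave open whether the large step depends on the thiophene ring's point of attachment, as thiophen-2-yl would test, and how a pyridine ring or an amine would fare on the same carbon.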